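Aryl sulfonamides: three limits, one untested analogue

The source may hold more compounds than are shown below. What is called first, only, known or untested is meant among the compounds shown, and "the series" means these compounds.

compound 1 `O=S(=O)(Nc1ccc(-c2nc3ccccc3o2)cc1)c1ccc(Cl)c(C(F)(F)F)c1`: > 63000 nM
compound 2 `O=S(=O)(Nc1ccc(-c2nc3ccccc3o2)cc1)c1ccc(Cl)s1`: > 63000 nM
compound 3 `O=S(=O)(Nc1ccc2oc(-c3ccccc3)nc2c1)c1cccc(F)c1`: > 63000 nM

In an assay on isolated protein for inhibition of malate dehydrogenase, mitochondrial (Sus scrofa), with stated times of 45 min and 30 min (on this read-out higher numbers stand for weaker inhibition and lower numbers for stronger inhibition), compound 1 returns only a limit, > 63000 nM. Compound 2 likewise gives a limit, > 63000 nM. Compound 3 also gives a limit, > 63000 nM. Among the compounds with values here, compound 2 therefore stands with the other two at the top of the measurable range, as the limit of > 63000 nM in this assay, at which 3 of the 3 values shown sit, records, and no measured step separates any pair.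

Compound 4 `COc1ccc(S(=O)(=O)Nc2ccc(-c3nc4ccccc4o3)cc2)cc1` differs from compound 2 in one place: 4-methoxyphenyl in place of 5-chlorothiophen-2-yl on a sulfonyl sulfur. Within the data shown here, no measured compound shows what a change on the sulfonyl sulfur does in this assay. Compound 4 is expected to stay at or near the limit, an expected step that the limit leaves unreadable from compound 2 to compound 4 that lies within the scatter. Compound 4 is estimated at 100000 nM, with a range from 30000 nM to 500000 nM.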

Compound 4, half-maximal inhibitory concentration: > 63000 nM
Compound 4: a limit, no number (the forecaster's own chance of this, stated with the estimate: 80%); the middle value is on the limit's open side.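

Within the data shown here, compound 2 and compound 4 both return only limits, and no step between them can be read in this assay. The compounds shown leave open whether any change on the sulfonyl sulfur gives a measurable value.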